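From compound 1 to compound 4: notes on one step

The source may hold more compounds than are shown below. What is called first, only, known or untested is meant among the compounds shown, and "the series" means these compounds.

Values in a functional assay on OVCAR-3 cells (Homo sapiens) for antiproliferative activity, read by MTT assay, with a stated time of 24 h (a higher number here means a weaker inhibitor, a lower number a stronger inhibitor), follow
Compound 1 (`O=C(NNc1cccc(Cl)c1)c1ccccc1NS(=O)(=O)c1cnc(O)nc1O`): 5520 nM
Compound 2 (`O=C(NNC(=O)c1cccc(Cl)c1)c1ccc(NS(=O)(=O)c2cnc(O)nc2O)cc1`): 7710 nM
Compound 3 (`O=C(NNC(=O)c1cccc(NS(=O)(=O)c2cnc(O)nc2O)c1)c1ccc(F)cc1`): > 20000 nM (a limit)

Among the compounds with values here, compound 1 and compound 2 give the only two numbers in the set, and they lie within the scatter of each other. The entry for compound 3 is a limit.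

Compound 4 (`Cc1ccc(C(=O)NNC(=O)c2ccccc2NS(=O)(=O)c2cnc(O)nc2O)cc1`) carries (4-methylphenyl)carbonyl in place of 3-chlorophenyl on an amine nitrogen. Within the data shown here, no measured step covers this change. Compound 2 also bears an aromatic carbonyl on such a nitrogen, on a different core, and gives 7710 nM in this assay, so only a small move towards a higher number is expected. The expected 1.6-fold higher number from compound 1 to compound 4 (0.21 log units; within the scatter) stays within the scatter. For compound 4 the estimated value is 9000 nM, with an expected range from 3500 nM to 22000 nM.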

Compound 4, half-maximal inhibitory concentration: 12900 nM
Estimate against measurement, compound 4: 1.4-fold (0.16 log units) below, within the range that was stated.
By their numbers in this assay, from the lowest: compounds 1, 2 and 4 (each within the scatter of the next, the first and the last beyond it). At a limit, above all of these: compound 3.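

In this assay, within the data shown here, (4-methylphenyl)carbonyl in place of 3-chlorophenyl on an amine nitrogen gives a 2.3-fold higher number from compound 1 to compound 4 (0.37 log units; beyond the scatter) as the first measured step at this position. The position therefore registers this exchange on the core of compound 1, and the change is a modest one. Nothing measured here bears on the reason for the step.

The exchange adds the carbonyl and alters the ring substituents in one move, so the compounds shown do not separate these parts. From the compounds shown here alone, how acetyl or a carboxylic acid on this nitrogen would read remains open.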